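This account rests on a few compounds, and the source may have more. Where it says the series, first, only, none or still open, it means among the compounds named here.

Working notes on the series. Compound 1 `CS(=O)(=O)c1ccccc1C(=O)N1CCC(N(C2CC2)S(=O)(=O)c2cccc(C(F)(F)F)c2)CC1` gives 39% in an assay on cells for inhibition of Voltage-dependent L-type calcium channel subunit alpha-1C (Homo sapiens), read by FLIPR and calcium flux, tested at 3 uM; a higher number here means a stronger effect of the compound at the concentration tested, a lower number a weaker effect. Compound 2 `O=C(c1ccccc1OC(F)(F)F)N1CCC(N(C2CC2)S(=O)(=O)c2cccc(C(F)(F)F)c2)CC1` gives "not determined" (no result reported) in this assay and so stands on no number of its own. Compound 3 `O=C(c1cccc(OC(F)(F)F)c1)N1CCC(N(C2CC2)S(=O)(=O)c2cccc(C(F)(F)F)c2)CC1` differs from compound 2 in one place: 3-(trifluoromethoxy)phenyl in place of 2-(trifluoromethoxy)phenyl on a carbonyl carbon. Among the measured compounds shown here, no step between two measured compounds of this kind is available, so the size of the step from compound 2 to compound 3 in this assay cannot be anchored; a small change in either direction, hardly beyond the scatter, is expected. Compound 3 is estimated at 38% in this assay, with an expected range from 12% to 65%.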

Compound 3, a percentage reported as inhibition, at one concentration (the size of the read-out at that concentration, not a potency): 78%
Compound 3: the middle estimate sits 40 percentage points below what was measured, outside the stated range (above it).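

At the carbonyl carbon, 3-(trifluoromethoxy)phenyl in place of 2-(methylsulfonyl)phenyl gives a number 39 percentage points higher from compound 1 to compound 3 (beyond the scatter) in this assay and shows that this position can carry a large change in the read-out. The step swaps both the group and its ring placement, so it does not separate the two, and the step from compound 2 cannot be read. Nothing available accounts for the change.
Open, from the compounds shown here alone, is whether 3-(methylsulfonyl)phenyl or unsubstituted phenyl would hold the read-out of compound 3, which would show whether the trifluoromethoxy group or its placement carries the step.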